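A few compounds are considered here, and "the series" means these few. Any claim that something is new, unique, unknown or untested is made for them only; others in the source may bear on it.

Compound 1 `COc1cc(Cl)cc(-c2nn(-c3cccc(NC(=O)c4cccc(C(F)(F)F)c4)c3)cc2-c2ccncc2)c1` gives 46.7%. Compound 2 `O=C(Nc1cccc(-n2cc(-c3ccncc3)c(-c3cc(O)cc(Cl)c3)n2)c1)c1cc(C(F)(F)F)cc(C(F)(F)F)c1` gives 46.9%.

Both numbers come from a functional assay on NCI/ADR-RES cells (Homo sapiens) for inhibition, read by sulforhodamine B assay, with a stated time of 48 h, tested at 10 uM; on this read-out higher numbers stand for a weaker effect at the one concentration tested and lower numbers for a stronger effect. Compound 2 and compound 1 sit essentially on the same number, separated by a gap that lies inside the usual scatter, so the two cannot be told apart. Compound 3 `COc1cc(Cl)cc(-c2nn(-c3cccc(NC(=O)c4cc(C(F)(F)F)cc(C(F)(F)F)c4)c3)cc2-c2ccncc2)c1` differs from compound 2 by methyl in place of hydrogen on an oxygen on an aromatic ring. Among the measured compounds shown here, no measured pair shows this change on its own, so no size can be read from the numbers. The step of a number 0.1 percentage points higher from compound 2 to compound 3 (within the scatter) is expected to stay within the scatter. The estimate for compound 3 in this assay is 47%, ranging from 34% to 60%.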

Compound 3, a percentage reported as activity, at one concentration (the size of the read-out at that concentration, not a potency): 67.8%
The estimate for compound 3 lay 20.8 percentage points below the measured number, and the stated range ends below it.
By their numbers in this assay, from the lowest: compounds 1 and 2 (each within the scatter of the next); then compound 3.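

Hydroxy to methoxy on the 3-chloro-5-hydroxyphenyl group is not a silent swap: in this assay it gives a number 20.9 percentage points higher from compound 2 to compound 3 (beyond the scatter) and so a weaker effect. Trifluoromethyl in place of hydrogen on an aromatic carbon, with the methoxy kept, gives a number 21.1 percentage points higher from compound 1 to compound 3 (beyond the scatter) and also weakens the effect. Nothing available here explains either step.

As far as these compounds go, whether the hydrogen on that oxygen or the size of the group there drives the first step stays open. An amine or an ethoxy group in that place could begin to separate the two.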